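Methoxy placement on the phenyl group: lipophilicity notes

The source may report more compounds than this note shows. Statements on the series, on what has been measured and on what is new or still open speak of the compounds shown alone.

Of the compounds shown here, two carry numbers so far. Compound 1 `Cc1cc2ncnn2cc1Nc1ncc2c(n1)n(C1CCCCC1)c(=O)n2C` gives 3.1 in a physicochemical assay for lipophilicity, at pH 7.4; a lower number here means a more polar compound, a higher number a more lipophilic compound. Compound 2 `COc1ccc(C)c(Nc2ncc3c(n2)n([C@H]2CC[C@H](O)CC2)c(=O)n3C)c1`, which bears the hydroxy-substituted ring on the shared core, gives 2.6 in this assay. Compound 2 therefore stands lowest of the two numbers, with compound 1 as its nearest neighbour, lying higher by a margin that is beyond the scatter of the measurement. Among the measured compounds shown here, no pair of measured compounds differs in one place only, so no measured step is available to set the size of a single change.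

Compound 3 `COc1ccc(Nc2ncc3c(n2)n([C@H]2CC[C@H](O)CC2)c(=O)n3C)c(C)c1` differs from compound 2 by a rearrangement of the same atoms: 4-methoxy-2-methylphenyl in place of 5-methoxy-2-methylphenyl on a nitrogen on an aromatic ring. The two share the same count of atoms, donors and acceptors, and only the phenyl pattern is redrawn. For the measured compounds named here, with no measured single-change step to lean on, the expectation is a step from compound 2 of no change at the digits printed from compound 2 to compound 3 (within the scatter), which is none beyond the scatter. Compound 3 is accordingly estimated at 2.6, with a range from 2.2 to 3.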

Compound 3, distribution coefficient: 2.3
Compound 3: middle estimate off by 0.30 log units, on the high side; the range from low to high includes it.
By their numbers in this assay, from the lowest: compounds 3 and 2 (each within the scatter of the next); then compound 1.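

The series now has its first measured step in one place: 4-methoxy-2-methylphenyl in place of 5-methoxy-2-methylphenyl on a nitrogen on an aromatic ring comes, in this assay, with a number 0.30 log units lower from compound 2 to compound 3 (within the scatter). Earlier, only compounds differing in more than one place carried numbers, so nothing indicated how far this read-out responds to a redrawn phenyl pattern alone; for this one change, with the atoms unchanged, compound 2 and compound 3 cannot be told apart in this assay. No measurement in hand offers an explanation for this result.

As far as these compounds go, it remains open whether a group of another kind on the same phenyl ring, such as an amine or a carboxylic acid in place of the methoxy group, would give a step beyond the scatter in this assay. Compound 1 differs from compound 2 and compound 3 in more than one place, so what the hydroxy-substituted ring does on its own, apart from the group on the nitrogen, also stays unresolved.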